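Swapping cyano for chloro in a carbamoyl sulfonamide

The source may hold more compounds than are shown below. What is called first, only, known or untested is meant among the compounds shown, and "the series" means these compounds.

compound 1 `N#Cc1ccc(S(=O)(=O)Nc2cccc3c(C#N)c[nH]c23)cc1`: 0.53 ug/mL
compound 2 `N#Cc1c[nH]c2c(NS(=O)(=O)c3ccc(C(N)=O)cc3)cccc12`: 2.5 ug/mL
compound 3 `N#Cc1c[nH]c2c(NS(=O)(=O)c3ccc(N)cc3)cccc12`: 0.72 ug/mL

In a functional assay on P388 cells (Mus musculus) for antiproliferative activity (a higher number here means a weaker inhibitor, a lower number a stronger inhibitor), compound 2 gives 2.5 ug/mL, the highest number of the three and beyond the scatter from both others. Compound 4 `NC(=O)c1ccc(S(=O)(=O)Nc2cccc3c(Cl)c[nH]c23)cc1` keeps its carbamoyl group but carries chloro in place of cyano on an aromatic carbon of the five-membered aromatic ring: chloro in place of cyano on an aromatic carbon. Among the compounds with values here, no measured step touches that place. The three available steps swap a different group: a 4.7-fold higher number from compound 1 to compound 2 (0.67 log units; beyond the scatter), a 3.5-fold lower number from compound 2 to compound 3 (0.54 log units; beyond the scatter) and a 1.4-fold higher number from compound 1 to compound 3 (0.13 log units; within the scatter). Within the data shown here, they show only that single swaps in this small set stayed modest in size, so no clear direction can be drawn, and no step beyond the scatter is expected: a 1.3-fold lower number from compound 2 to compound 4 (0.10 log units; within the scatter). Compound 4 is expected at 2 ug/mL, with an estimated range of 0.6 ug/mL to 7 ug/mL.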

Compound 4, half-maximal inhibitory concentration: 0.87 ug/mL
Beside the measured number, compound 4's estimate is 2.3-fold (0.36 log units) above it, within the range that was stated.
By their numbers in this assay, from the lowest: compounds 1, 3 and 4 (each within the scatter of the next); then compound 2.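

In this assay, chloro in place of cyano on this aromatic carbon of the five-membered ring gives a 2.9-fold lower number from compound 2 to compound 4 (0.46 log units; beyond the scatter). Within the data shown here, the earlier compounds all kept cyano here, so this is the first sign that this place affects the number, and the step is modest. It is read only with the carbamoyl group in place, and nothing available explains it. As far as these compounds go, whether chloro gives a similar step alongside the cyano or amino groups of the other compounds stays open. So does how bromo or methyl on this carbon would compare.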